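The source may hold more compounds than are shown below. What is called first, only, known or untested is meant among the compounds shown, and "the series" means these compounds.

Compound 3 `COc1ccc(F)cc1CNCCCNc1ccnc2cc(Cc3ccccc3)ccc12` gives 23 10^-6 cm/s in an ADME assay for permeability, using PAMPA, with a stated time of 30 min, at pH 7.4; a higher number here means that the compound crosses the layer faster, a lower number that the compound crosses the layer more slowly. Compound 1 `COc1ccc(F)cc1CNCCCNc1ccnc2cc(CCC(C)C)ccc12` gives 23 10^-6 cm/s in this assay, and no change at the digits printed from compound 1 to compound 3 (within the scatter); together the two stand as the lowest of the three numbers. Compound 2 `COc1ccc(F)cc1CNCCCNc1ccnc2cc(-c3ccccc3)ccc12` gives 237 10^-6 cm/s in this assay, and a 10-fold lower number from compound 2 to compound 3 (1.01 log units; beyond the scatter). Compound 4 `COc1ccc(F)cc1CNCCCNc1ccnc2cc(-c3cccc4ccccc34)ccc12` is the next step from compound 3: naphthalen-1-yl in place of benzyl on an aromatic carbon. Among the measured compounds shown here, the steps that bear on it are a 10-fold higher number from compound 1 to compound 2 (1.01 log units; beyond the scatter) and a 10-fold lower number from compound 2 to compound 3 (1.01 log units; beyond the scatter), both large. A large upward step, a 6.5-fold higher number from compound 3 to compound 4 (0.81 log units; beyond the scatter), is expected because a 10-fold lower number from compound 2 to compound 3 (1.01 log units; beyond the scatter) ran the other way when benzyl replaced phenyl on the same aromatic carbon, and because a 10-fold higher number from compound 1 to compound 2 (1.01 log units; beyond the scatter) rose when an aryl entered there. Compound 4 is therefore estimated at 150 10^-6 cm/s, within 50 10^-6 cm/s to 400 10^-6 cm/s.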

Compound 4, apparent permeability: 237 10^-6 cm/s
Compound 4: middle estimate off by 1.6-fold (0.20 log units), on the low side; low and high end bracket the measured number.
By their numbers in this assay, from the lowest: compounds 1 and 3 (each within the scatter of the next); then compounds 2 and 4 (each within the scatter of the next).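

In this assay the step of no change at the digits printed from compound 2 to compound 4 (within the scatter) shows that the second fused ring of naphthalen-1-yl leaves the number level with phenyl on this aromatic carbon. Among the compounds shown here, with a 10-fold higher number from compound 3 to compound 4 (1.01 log units; beyond the scatter) and a 10-fold higher number from compound 1 to compound 4 (1.01 log units; beyond the scatter) the four compounds split into two levels: aryl groups bound directly to this carbon in compounds 2 and 4, and benzyl and isopentyl in compounds 3 and 1, with no compound going against the split. No evidence at hand accounts for this split. Open, from the compounds shown here alone, is whether a pyridine ring or a phenyl ring carrying a carboxylic acid stays at the level of compound 4. Also open, going by these compounds, is where a longer chain ending in phenyl falls.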